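Swapping methoxy for dimethylamino on the aryl ring

This account rests on a few compounds, and the source may have more. Where it says the series, first, only, none or still open, it means among the compounds named here.

Compound 2 `COc1ccc(/C=N\NC(=S)NC(C)(C)CCC[C@](C)(O)[C@@H]2CC=C(C)CC2)cc1` gives 57000 nM in a functional assay on NCI/ADR cells (Homo sapiens) for cytotoxicity, read by sulforhodamine B assay (a higher number here means a weaker inhibitor of growth, a lower number a stronger inhibitor of growth), the highest of the two numbers measured, although its gap to compound 1 lies within the scatter. Going by the values given here, compound 1 `CC1=CC[C@@H]([C@@](C)(O)CCCC(C)(C)NC(=S)NN)CC1` gives 29000 nM in this assay, and the only measured step is a 2.0-fold higher number from compound 1 to compound 2 (0.29 log units; within the scatter). Compound 3 `CC1=CC[C@@H]([C@@](C)(O)CCCC(C)(C)NC(=S)N/N=C\c2ccc(N(C)C)cc2)CC1` differs from compound 2 by dimethylamino in place of methoxy on an aromatic carbon. Among the compounds with values here, no measured step covers this change, so there is no basis for expecting a shift beyond the scatter; the expected step is a 1.1-fold lower number from compound 2 to compound 3 (0.06 log units; within the scatter). Compound 3 is therefore estimated at 50000 nM, with a range from 15000 nM to 160000 nM.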

Compound 3, concentration for total growth inhibition: > 100000 nM
Compound 3: a limit, no number (the forecaster's own chance of this, stated with the estimate: 10%); middle value at least 2.0-fold (0.30 log units) away from the limit.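

In this assay the reading for compound 3 is a limit and not a number: the limit of > 100000 nM in this assay, at which 1 of the 3 values shown sits. Dimethylamino in place of methoxy on the aromatic ring gives an at least 1.7-fold higher number from compound 2 to compound 3 (0.24 log units; that floor lies within the scatter) and fixes no size for the gap, which may be larger than that floor. This first change on the ring itself brings no stronger inhibition of growth, a point compounds 1 and 2 could not address. From the compounds shown here alone, whether a hydroxyl, a chlorine or a carboxylic acid at this place would give a lower number remains open.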